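Compound 3 Solubility Expected Close to Compound 1

The source may hold more compounds than are shown below. What is called first, only, known or untested is meant among the compounds shown, and "the series" means these compounds.

Compound 1 `O=C(c1ccc(Cl)cc1)N1CCC(NS(=O)(=O)c2cc(S(=O)(=O)c3ccccc3)ccc2C(F)(F)F)CC1` gives 3100 nM in a physicochemical assay for solubility (on this read-out lower numbers stand for lower solubility and higher numbers for higher solubility), the lowest of the two numbers recorded. Compound 2 `N#Cc1cccc(S(=O)(=O)N2CCC(NS(=O)(=O)c3cc(S(=O)(=O)c4ccccc4)ccc3C(F)(F)F)CC2)c1` gives 6300 nM in this assay, and the step of a 2.0-fold higher number from compound 1 to compound 2 (0.31 log units; beyond the scatter) is modest. Compound 3 `CC(C)(C)OC(=O)N1CC[C@H](C(=O)N2CCC(NS(=O)(=O)c3cc(S(=O)(=O)c4ccccc4)ccc3C(F)(F)F)CC2)C1` differs from compound 1 by 1-(tert-butoxycarbonyl)pyrrolidin-3-yl in place of 4-chlorophenyl on a carbonyl carbon. Within the data shown here, no measured step matches this change; the only step available, a 2.0-fold higher number from compound 1 to compound 2 (0.31 log units; beyond the scatter), alters the same region of the shared core with a different group and is a loose guide at best. A modest step upward, or none beyond the scatter, is therefore expected. For compound 3 the estimated value is 4000 nM, with a range from 1500 nM to 12000 nM. This corresponds to an expected step of a 1.3-fold higher number from compound 1 to compound 3 (0.11 log units; within the scatter).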

Compound 3, solubility: 25000 nM
Estimate against measurement, compound 3: 6.3-fold (0.80 log units) below; the whole stated range lies below it.
By their numbers in this assay, from the lowest: compound 1; then compound 2; then compound 3.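

With the carbonyl kept, replacing only the 4-chlorophenyl on the carbonyl carbon with 1-(tert-butoxycarbonyl)pyrrolidin-3-yl gives an 8.1-fold higher number from compound 1 to compound 3 (0.91 log units; beyond the scatter) in this assay. This shows that the group at this position alone can move the read-out beyond the scatter, whereas the earlier step also replaced the carbonyl. No measurement here bears on why the number rises. The compounds shown leave open whether the step follows the non-aromatic ring or the tert-butoxycarbonyl group. A cyclohexyl group or a pyrrolidin-3-yl group carrying a free ring amine would separate the two.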